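The Same Methyl, Added Twice: Estimating Lipophilicity

This account rests on a few compounds, and the source may have more. Where it says the series, first, only, none or still open, it means among the compounds named here.

Three compounds have been measured in a physicochemical assay for lipophilicity; on this read-out higher numbers stand for higher lipophilicity and lower numbers for lower lipophilicity:

Compound 1, `COC(=O)C1C(=O)C=C(Nc2ccc(N3CCN(C)CC3)cc2)CC1c1ccccc1`, gives 4.02.
Compound 2, `CCN1CCN(c2ccc(NC3=CC(=O)C(C(=O)OC)C(c4ccccc4)C3)cc2)CC1`, gives 4.39.
Compound 3, `CCOC(=O)C1C(=O)C=C(Nc2ccc(N3CCN(C)CC3)cc2)CC1C`, gives 3.07.

Compound 2 differs from compound 1 by methyl in place of hydrogen on a saturated chain carbon bound to an amine nitrogen in a ring, and that change brought a number 0.37 log units higher from compound 1 to compound 2 (beyond the scatter). Compound 3 has the lowest value of the three, and how its core differs from that of compound 1 is not broken down here.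

Compound 4, `CCOC(=O)C1C(=O)C=C(Nc2ccc(N3CCN(CC)CC3)cc2)CC1C`, has not yet been measured. It differs from compound 3 by methyl in place of hydrogen on a saturated chain carbon bound to an amine nitrogen in a ring, the same change at the same place. Because the earlier step gave a number 0.37 log units higher from compound 1 to compound 2 (beyond the scatter), a similar rise is expected here, estimated as a number 0.37 log units higher from compound 3 to compound 4 (beyond the scatter). On that basis compound 4 is expected to reach about 3.44 in this assay, most likely between 3.1 and 3.8.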

Compound 4, partition coefficient: 3.45
For compound 4 the middle estimate is 0.01 log units below the measured one; the range from low to high includes it.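

In this assay the change from 4-methylpiperazin-1-yl to 4-ethylpiperazin-1-yl gave a number 0.38 log units higher from compound 3 to compound 4 (beyond the scatter) on one core, nearly the same size as a number 0.37 log units higher from compound 1 to compound 2 (beyond the scatter) on the other core. This shows that the change carried over closely between these two cores, but two pairs make no rule for other cores in the series. Nothing shown here explains why the two steps agree.

The compounds shown leave open whether a longer chain, such as propyl, in place of the ethyl would raise the number further. They also leave open how a carboxylic acid on that chain would change it.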